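The compounds below may be only part of what the source reports. "The series", "measured", "known", "first", "only" and "open" are said of these compounds alone.

Measured so far:
compound 1 `Cc1c(OC2CCN(C)CC2)ccc2cc(NC(=O)c3ccc(O)c(CCC(C)C)c3)c(=O)oc12`, in a functional assay on MCF7 cells (Homo sapiens) for antiproliferative activity; on this read-out higher numbers stand for weaker inhibition and lower numbers for stronger inhibition: 1250 nM
compound 2 `CC(C)=CCc1cccc(C(=O)Nc2cc3ccc(OC4CCN(C)CC4)c(C)c3oc2=O)c1`, in this assay: 2100 nM

Compound 2 gives the larger of the two numbers, but its gap to compound 1 lies within the scatter, so the two cannot be ranked. Compound 3 `C=CCc1cc(C(=O)Nc2cc3ccc(OC4CCN(C)CC4)c(C)c3oc2=O)ccc1O` is not yet measured; it differs from compound 2 in 3-allyl-4-hydroxyphenyl in place of 3-(3-methylbut-2-en-1-yl)phenyl on a carbonyl carbon. Compound 1 likewise carries a hydroxy group and in this assay compound 1 gives 1250 nM. Because compound 1 gives 1250 nM, the expected step of a 1.6-fold lower number from compound 2 to compound 3 (0.21 log units; within the scatter) is small, toward a lower number, and may not exceed the scatter. Compound 3 is estimated at 1300 nM, range 500 nM to 3500 nM.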

Compound 3, half-maximal inhibitory concentration: 2170 nM
Estimate against measurement, compound 3: 1.7-fold (0.22 log units) below; low and high end bracket the measured number.
By their numbers in this assay, from the lowest: compounds 1, 2 and 3 (each within the scatter of the next).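

In this assay, 3-allyl-4-hydroxyphenyl in place of 3-(3-methylbut-2-en-1-yl)phenyl on a carbonyl carbon (a 1.0-fold higher number from compound 2 to compound 3 (0.01 log units; within the scatter)) adds a hydrogen-bond donor without a readable effect. Vinyl in place of isobutyl on a saturated chain carbon bound to an aromatic carbon (a 1.7-fold higher number from compound 1 to compound 3 (0.24 log units; within the scatter)) likewise stays within the scatter. No supporting data bear on either step.

Open, from the compounds shown here alone, is whether an amine or a longer chain in place of the allyl group would move the number beyond the scatter.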